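This account rests on a few compounds, and the source may have more. Where it says the series, first, only, none or still open, it means among the compounds named here.

Compound 3 `COc1cc2c(Oc3ccc(NC(=O)c4nn(-c5ccccc5)c(=O)c5ccccc45)cc3F)ccnc2cc1OCCCN1CCC(C)CC1` gives 580 nM in a functional assay on MKN-45 cells (Homo sapiens) for cytotoxicity, read by MTT assay, with a stated time of 72 h (on this read-out higher numbers stand for weaker inhibition and lower numbers for stronger inhibition), and the two other measured compounds sit within the scatter of that number: compound 2 `COc1cc2c(Oc3ccc(NC(=O)c4nn(-c5ccccc5)c(=O)c5ccccc45)cc3F)ccnc2cc1OCCCN1CCCCC1` gives 590 nM and compound 1 `COc1cc2c(Oc3ccc(NC(=O)c4nn(-c5ccccc5)c(=O)c5ccccc45)cc3F)ccnc2cc1OCCCN1CCN(C)CC1` gives 620 nM. The measured steps, a 1.1-fold lower number from compound 1 to compound 2 (0.02 log units; within the scatter), a 1.1-fold lower number from compound 1 to compound 3 (0.03 log units; within the scatter) and a 1.0-fold lower number from compound 2 to compound 3 (0.01 log units; within the scatter), all concern the amine at the end of the chain and were all within the scatter. Compound 4 `COc1cc2c(Oc3ccc(NC(=O)c4nn(-c5ccc(Br)cc5)c(=O)c5ccccc45)cc3F)ccnc2cc1OCCCN1CCC(C)CC1` differs from compound 3 at a different place: bromo in place of hydrogen on an aromatic carbon. Within the data shown here, no measured step touches this ring, so nothing here tells how large such a change will be. The expectation is therefore a step of a 1.3-fold lower number from compound 3 to compound 4 (0.11 log units; within the scatter), not beyond the scatter. Compound 4 is expected to give about 450 nM in this assay, within a range of 150 nM to 1500 nM.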

Compound 4, half-maximal inhibitory concentration: 330 nM
Compound 4: the middle estimate sits 1.4-fold (0.13 log units) above what was measured; measured number inside the range.
By their numbers in this assay, from the lowest: compounds 4, 3, 2 and 1 (each within the scatter of the next).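

In this assay, going from phenyl to 4-bromophenyl gives a 1.8-fold lower number from compound 3 to compound 4 (0.24 log units; within the scatter). This is the first change shown away from the amine at the end of the chain, and like the amine changes, it stays within the scatter, so a bromo group on this ring leaves the reading close to that of the unsubstituted phenyl. No measurement here offers an explanation for this small step. As far as these compounds go, whether a chloro, methoxy or nitrile group in the same place, or a bromo on another carbon of this ring, would give a step beyond the scatter remains open.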